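Amide substituent change on the pyridine-carboxamide solubility series

The source may hold more compounds than are shown below. What is called first, only, known or untested is meant among the compounds shown, and "the series" means these compounds.

Measured so far:
compound 1 `Cn1ccc2ccc(-c3cc(Nc4ccccc4S(=O)(=O)N4CCOCC4)cc4nccnc34)cc21` — 5 ug/mL
compound 2 `CN(Cc1cncnc1)S(=O)(=O)c1ccccc1Nc1cc(-c2ccc3ccn(C)c3c2)c2nccnc2c1` — 3 ug/mL
compound 3 `CN(C)C(=O)c1ccncc1Nc1cc(-c2ccc3ccn(C)c3c2)c2nccnc2c1` — 175 ug/mL

Compound 3 holds the highest number of the three in a physicochemical assay for solubility, read by spectrophotometry, measured as kinetic solubility, at pH 8, tested at 500 uM; on this read-out higher numbers stand for higher solubility and lower numbers for lower solubility; its margins over compound 1 and compound 2 are beyond the scatter. Compound 4 `CC(=O)N1CC(CNC(=O)c2ccncc2Nc2cc(-c3ccc4ccn(C)c4c3)c3nccnc3c2)C1` carries ((1-acetylazetidin-3-yl)methyl)amino in place of dimethylamino on a carbonyl carbon. Among the compounds with values here, the one measured step, a 1.7-fold lower number from compound 1 to compound 2 (0.22 log units; within the scatter), concerns a sulfonyl substituent, not the carbonyl carbon, and was within the scatter, so it gives little direct guidance. Within the data shown here, no measured step bears on the present change. Compound 4 is therefore expected to sit near compound 3, with an estimated step of a 1.3-fold lower number from compound 3 to compound 4 (0.10 log units; within the scatter) not clearly beyond the scatter. The expected value for compound 4 is 140 ug/mL, with a range from 50 ug/mL to 250 ug/mL.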

Compound 4, solubility: 252 ug/mL
Compound 4: the middle estimate sits 1.8-fold (0.26 log units) below what was measured; the whole stated range lies below it.
By their numbers in this assay, from the lowest: compounds 2 and 1 (each within the scatter of the next); then compounds 3 and 4 (each within the scatter of the next).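

In this assay, ((1-acetylazetidin-3-yl)methyl)amino replaces dimethylamino on the carbonyl carbon with a 1.4-fold higher number from compound 3 to compound 4 (0.16 log units; within the scatter), so the two compounds cannot be separated on this read-out. This position therefore accepts a substantially larger group, carrying a four-membered non-aromatic ring and a hydrogen-bond donor, with no loss of solubility beyond the scatter. Nothing available explains this result.

Whether the acetyl group contributes remains open, as no compound shown has the azetidine without it. Also open, from the compounds shown here alone, is how a basic amine or a carboxylic acid in the same place would read.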